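Swapping the ketone's ring: thiophene out, dimethoxyphenyl in

The compounds below may be only part of what the source reports. "The series", "measured", "known", "first", "only" and "open" are said of these compounds alone.

Measured so far:
compound 1 `O=C(/C=C/c1cn(-c2ccccc2)nc1-c1cccnc1)c1ccsc1` gives 1700 nM in a functional assay on Huh-7 cells (Homo sapiens) for inhibition, read by sulforhodamine B assay, with a stated time of 72 h; on this read-out higher numbers stand for weaker inhibition and lower numbers for stronger inhibition
compound 2 `COc1cc(C(=O)/C=C/c2cn(-c3ccccc3)nc2-c2cccnc2)cc(OC)c1OC` gives 1900 nM in this assay
compound 3 `O=C(/C=C/c1cn(-c2ccccc2)nc1-c1ccncc1)c1ccsc1` gives 2200 nM in this assay

All three compounds share the same core and differ only in one ring at either end. Their numbers sit close together: compound 1 and compound 3 are separated by a 1.3-fold higher number from compound 1 to compound 3 (0.11 log units; within the scatter), and compound 2 and compound 3 show values that also lie within the usual scatter of each other. Compound 3 therefore cannot be called weaker or stronger than either companion on the numbers shown.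

Compound 4 `COc1ccc(C(=O)/C=C/c2cn(-c3ccccc3)nc2-c2ccncc2)cc1OC` is compound 3 with 3,4-dimethoxyphenyl in place of thiophen-3-yl on a carbonyl carbon. For the measured compounds named here, no measured step repeats exactly this change. The closest guide is the pair compound 1 and compound 2, which differ by exchanging thiophen-3-yl for 3,4,5-trimethoxyphenyl on the same carbonyl carbon; their values are within the scatter of each other. The listed step from compound 1 to compound 3 concerns the other end of the molecule and carries no information on the carbonyl-side ring.

On this basis, no movement beyond the scatter is expected, and compound 4 is estimated at 2300 nM, between 1000 nM and 5000 nM, which corresponds to an expected step of a 1.0-fold higher number from compound 3 to compound 4 (0.02 log units; within the scatter).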

Compound 4, half-maximal inhibitory concentration: 2000 nM
For compound 4 the middle estimate is 1.2-fold (0.06 log units) above the measured one; the range from low to high includes it.
By their numbers in this assay, from the lowest: compounds 1, 2, 4 and 3 (each within the scatter of the next).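

In this assay the exchange of thiophen-3-yl for 3,4-dimethoxyphenyl on the carbonyl carbon yields a 1.1-fold lower number from compound 3 to compound 4 (0.04 log units; within the scatter), so this exact change has now been read directly, in a pair of compounds that differ in this one place. A five-membered aromatic ring with 1 hetero atom and 5 heavy atoms can therefore give way on this carbonyl carbon to a six-membered aromatic ring of carbon only with 10 heavy atoms, and the two numbers still cannot be told apart. Nothing measured here offers an explanation of this result.

The compounds shown leave open whether any group on this carbonyl carbon can move the number beyond the scatter, since every ring shown there is an aromatic one. A carboxylic acid, a dimethylamino group or a longer alkyl chain in place of the ring would test this, and a result beyond the scatter would give the first clear sign that this part of the molecule matters in this assay.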